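Benzylsulfanyl for Methylsulfanyl on a Shared Triazole Core

The source may report more compounds than this note shows. Statements on the series, on what has been measured and on what is new or still open speak of the compounds shown alone.

Compound 1 `CCc1nnc(SCc2ccccc2)n1N1C(=O)c2ccccc2C1=O` — > 200000 nM
Compound 2 `CCc1nnc(SC)n1N1C(=O)c2ccccc2C1=O` — > 200000 nM
Compound 3 `COc1cc(-c2nnc(SC)n2N2C(=O)c3ccccc3C2=O)cc(OC)c1OC` — > 200000 nM

In a functional assay on A549 cells (Homo sapiens) for cytotoxicity, read by MTT assay, with a stated time of 48 h (on this read-out lower numbers stand for stronger inhibition and higher numbers for weaker inhibition), compound 1 reaches only the limit of the assay, > 200000 nM. Compound 2 likewise gives only a limit in this assay, > 200000 nM. Compound 3 too sits at a limit in this assay, > 200000 nM. The step that the two limits leave unreadable from compound 2 to compound 1 is therefore not readable, since both ends rest on (the limit of > 200000 nM in this assay, at which 3 of the 3 values shown sit). That step is the change (phenyl in place of hydrogen on a saturated chain carbon bound to a sulfur).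

Compound 4 `COc1cc(-c2nnc(SCc3ccccc3)n2N2C(=O)c3ccccc3C2=O)cc(OC)c1OC` has not yet been measured in this assay. It differs from compound 3 by phenyl in place of hydrogen on a saturated chain carbon bound to a sulfur, the same change as that from compound 2 to compound 1. The difference between the core of compound 2 and the core of compound 3 is not broken down here.

Among the measured compounds shown here, because every value so far sits at the limit of > 200000 nM in this assay, at which 3 of the 3 values shown sit, compound 4 is expected to give only a limit as well, a step that the limit leaves unreadable from compound 3 to compound 4 that cannot be read. Compound 4 is estimated at 250000 nM, between 100000 nM and 1000000 nM.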

Compound 4, half-maximal inhibitory concentration: > 200000 nM
Compound 4: no number, only a limit (the forecaster's own chance of this, stated with the estimate: 85%); the middle value is on the limit's open side.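

In this assay compound 4 also gives only a limit, > 200000 nM. The steps from compound 3 to compound 4 and from compound 1 to compound 4 therefore cannot be read, so no new step emerges: the limit of > 200000 nM in this assay, at which 4 of the 4 values shown sit.

The compounds shown leave open whether methylsulfanyl to benzylsulfanyl makes any difference on either core.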